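The compounds below may be only part of what the source reports. "The series", "measured", "known", "first", "only" and "open" are said of these compounds alone.

Measured so far:
compound 1 `COc1ccc(/C(=C\c2c[nH]c3ccc(OCc4ccccc4)cc23)C(=O)O)cc1` — "not determined" (no result reported)
compound 2 `COc1ccc(Cn2cc(/C=C(/C(=O)O)c3ccccc3)c3cc(OCc4ccccc4)ccc32)cc1` — 1000 nM
compound 3 `COc1ccccc1/C(=C\c1cn(C(C)=O)c2ccc(OCc3ccccc3)cc12)C(=O)O` — 57200 nM

Compound 3 holds the highest of the two numbers in a functional assay on A549 cells (Homo sapiens) for cytotoxicity, read by MTT assay, with a stated time of 72 h; on this read-out lower numbers stand for stronger inhibition and higher numbers for weaker inhibition; compound 2 sits far below it, beyond the scatter, and compound 1 contributes no number at all. Compound 4 `COc1cc(OC)cc(/C(=C\c2cn(C(C)=O)c3ccc(OCc4ccccc4)cc23)C(=O)O)c1` has not yet been measured. It differs from compound 3 by 3,5-dimethoxyphenyl in place of 2-methoxyphenyl on a double-bonded chain carbon bound to a carbonyl carbon and a double-bonded chain carbon. Within the data shown here, no measured pair in this assay carries this change, so nothing in the numbers shows its direction; the working expectation is a step within the scatter or at most a modest move, more likely toward a lower number than a higher one. Compound 4 is expected at 30000 nM in this assay, within a range of 8000 nM to 120000 nM. This amounts to an expected step of a 1.9-fold lower number from compound 3 to compound 4 (0.28 log units; within the scatter) in this assay.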

Compound 4, half-maximal inhibitory concentration: 26000 nM
Beside the measured number, compound 4's estimate is 1.2-fold (0.06 log units) above it; low and high end bracket the measured number.
By their numbers in this assay, from the lowest: compound 2; then compound 4; then compound 3.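

In this assay, among these compounds, the replacement of 2-methoxyphenyl by 3,5-dimethoxyphenyl on a double-bonded chain carbon bound to a carbonyl carbon and a double-bonded chain carbon gives a 2.2-fold lower number from compound 3 to compound 4 (0.34 log units; beyond the scatter) as the first single-place step. The number at this position therefore responds to the aryl substitution, though the step is only modest. No measurement at hand accounts for the step.

The change moves one methoxy group and adds another, so the two contributions cannot be separated. On these data alone, whether an amine on this phenyl ring would shift the number further remains open.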